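A few compounds are considered here, and "the series" means these few. Any claim that something is new, unique, unknown or untested is made for them only; others in the source may bear on it.

Working notes on the series. In a functional assay on A549 cells (Homo sapiens) for antiproliferative activity, read by MTT assay, with a stated time of 48 h (a higher number here means a weaker inhibitor of growth, a lower number a stronger inhibitor of growth), compound 1 (`CCOc1cc(NC(=O)CCCCCC(=O)Nc2cc(-c3ccccc3)ccc2N)cc2c1OCC([N+](=O)[O-])=C2`) gives 4860 nM. Compound 2 (`CCOc1cc(NC(=O)CCCCCCC(=O)Nc2cc(-c3ccccc3)ccc2N)cc2c1OCC([N+](=O)[O-])=C2`) gives 5400 nM. Within the data shown here, these two values lie within the scatter of each other, so compound 1 stands level with the only other measured compound.

Compound 3 (`CCOc1cc(NC(=O)CCCCCC(=O)Nc2ccccc2N)cc2c1OCC([N+](=O)[O-])=C2`) has not yet been measured in this assay. It departs from compound 1 at one place: hydrogen in place of phenyl on an aromatic carbon, with hydrogen in place of phenyl on an aromatic carbon.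

Among the measured compounds shown here, no measured pair covers this change, so the size of the step remains open. With compound 1 at 4860 nM as the anchor, a modest step toward a higher number in this assay is expected, possibly not beyond the scatter. The estimated step is a 1.4-fold higher number from compound 1 to compound 3 (0.16 log units; within the scatter). Compound 3 is expected at 7000 nM, with an estimated range of 2500 nM to 20000 nM.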

Compound 3, concentration for 50% growth inhibition: 12200 nM
For compound 3 the middle estimate is 1.7-fold (0.24 log units) below the measured one; the measured number falls inside the stated range.
By their numbers in this assay, from the lowest: compounds 1 and 2 (each within the scatter of the next); then compound 3.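

In this assay, hydrogen in place of phenyl on the aromatic carbon para to an amino group gives a 2.5-fold higher number from compound 1 to compound 3 (0.40 log units; beyond the scatter) and so makes compound 3 the weaker inhibitor of growth of this pair. Compounds 1 and 2 both carry the phenyl and could not show this; the step now shows that the phenyl at this position contributes modestly to growth inhibition, with compound 3 keeping measurable activity without it. No supporting measurement bears on the reason for the step, so the result stands without an assigned cause.

As far as these compounds go, whether a phenyl ring specifically is needed remains open, since a methyl group, a fluorine atom or a thienyl ring on the same carbon would test smaller or different substituents. From the compounds shown here alone, it also remains open whether the step holds with the longer chain of compound 2.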